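This account rests on a few compounds, and the source may have more. Where it says the series, first, only, none or still open, it means among the compounds named here.

Measured in a functional assay on A2780 cells (Homo sapiens) for antiproliferative activity, read by CellTiter-Glo, with a stated time of 4 days; on this read-out lower numbers stand for stronger inhibition and higher numbers for weaker inhibition:
compound 1 `CCC(=O)N[C@@H](C)c1ccc(NC(=O)[C@H]2C[C@@H]2c2cccnc2)cc1`: 5 nM
compound 2 `COCC(=O)N[C@@H](C)c1ccc(NC(=O)[C@H]2C[C@@H]2c2cccnc2)cc1`: 30 nM
compound 3 `C[C@H](NC(=O)c1ccc(C#N)cc1)c1ccc(NC(=O)[C@H]2C[C@@H]2c2cccnc2)cc1`: 4 nM

The three compounds differ only in the group on the carbonyl carbon of the amide. Compound 3 sits close to one of its two neighbours and well apart from the other. The measurements give a 1.3-fold lower number from compound 1 to compound 3 (0.10 log units; within the scatter), and they also give a 7.5-fold lower number from compound 2 to compound 3 (0.88 log units; beyond the scatter). The next compound, compound 4 `C[C@H](NC(=O)c1ccccn1)c1ccc(NC(=O)[C@H]2C[C@@H]2c2cccnc2)cc1`, has pyridin-2-yl in place of 4-cyanophenyl on a carbonyl carbon.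

For the measured compounds named here, no measured step covers this exchange directly, so the evidence is indirect. The exchange of ethyl for 4-cyanophenyl left the number within the scatter, which shows that two quite different groups can give matching values here. The other two steps show that this position is not indifferent, however: a 6.0-fold higher number from compound 1 to compound 2 (0.78 log units; beyond the scatter) came with methoxy in place of methyl. Compound 4 keeps a six-membered aromatic ring, so a small loss at most is expected in this assay, with no step beyond the scatter as the likeliest outcome. The expected change is a 1.8-fold higher number from compound 3 to compound 4 (0.24 log units; within the scatter). The estimate for compound 4 is 7 nM, with an expected range of 2 nM to 25 nM.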

Compound 4, half-maximal inhibitory concentration in the A2780 assay: 14 nM
For compound 4 the middle estimate is 2.0-fold (0.30 log units) below the measured one; low and high end bracket the measured number.
By their numbers in the A2780 assay, from the lowest: compounds 3 and 1 (each within the scatter of the next); then compound 4; then compound 2.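

In the A2780 assay the exchange of 4-cyanophenyl for pyridin-2-yl on this carbonyl carbon is not neutral: a 3.5-fold higher number from compound 3 to compound 4 (0.54 log units; beyond the scatter), so keeping a six-membered aromatic ring does not by itself hold the number at the level of compound 3. For the compounds shown here, also in the A2780 assay, compound 4 falls between the earlier compounds, with a 2.8-fold higher number from compound 1 to compound 4 (0.45 log units; beyond the scatter) and a 2.1-fold lower number from compound 2 to compound 4 (0.33 log units; beyond the scatter), which shows that the position separates two aromatic groups as well as an aromatic group from methoxymethyl. In a physicochemical assay for solubility, at pH 6.8 (on this read-out higher numbers stand for higher solubility and lower numbers for lower solubility), compound 3 gives 175000 nM and compound 4 gives 10000 nM. In the physicochemical assay compound 4 also falls behind compound 3, so this exchange loses ground on both read-outs instead of trading one for the other: the measured solubility of compound 3, 175000 nM, and of compound 4, 10000 nM, an 18-fold lower number (1.24 log units; beyond the scatter)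

The compounds shown leave open whether the weaker numbers of compound 4 go with the ring nitrogen of pyridin-2-yl or with the loss of the nitrile, and a plain phenyl group on the same carbonyl carbon would help to separate the two. A pyridine ring that carries a nitrile would test whether the two features can be combined at this position.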